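The source may report more compounds than this note shows. Statements on the series, on what has been measured and on what is new or still open speak of the compounds shown alone.

Three compounds have been measured in a functional assay on VCaP cells (Homo sapiens) for antiproliferative activity, read by propidium iodide staining, with a stated time of 96 h (a lower number here means a stronger inhibitor, a higher number a weaker inhibitor), so far:

Compound 1 `CC(O)(CSc1cccc(S(F)(F)(F)(F)F)c1)C(=O)Nc1ccc([N+](=O)[O-])c(C(F)(F)F)c1` gives 9800 nM
Compound 2 `CC(O)(CSc1cccc(S(F)(F)(F)(F)F)c1)C(=O)Nc1ccc([N+](=O)[O-])cc1C(F)(F)F` gives 28800 nM
Compound 3 `CC(O)(COc1ccc(S(F)(F)(F)(F)F)cc1)C(=O)Nc1ccc(C#N)c(C(F)(F)F)c1` gives 30100 nM

The number for compound 3 cannot be told apart from that of compound 2, as the two lie within the scatter of each other. Compound 1 has a lower number than compound 3 by more than the scatter, which makes compound 3 the weaker inhibitor of that pair.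

The next compound is compound 4 `CC(O)(COc1ccc(S(F)(F)(F)(F)F)cc1)C(=O)Nc1ccc([N+](=O)[O-])c(C(F)(F)F)c1` and it has not yet been measured. The change nitro in place of cyano on an aromatic carbon puts nitro in place of cyano on an aromatic carbon, ortho to a trifluoromethyl group and para to a large group.

Among the compounds with values here, no measured pair isolates this swap, so the expectation rests on thin evidence. Compound 1 also carries nitro ortho to a trifluoromethyl group and gives 9800 nM in this assay but the rest of its structure is not that of compound 4, so it is only a loose guide. The expected step of a 1.9-fold lower number from compound 3 to compound 4 (0.27 log units; within the scatter) is therefore small, toward a lower number and not clearly beyond the scatter. Compound 4 is expected at 16000 nM with an estimated range of 6000 nM to 40000 nM in this measurement.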

Compound 4, half-maximal inhibitory concentration: 100000 nM
The estimate for compound 4 lay 6.3-fold (0.80 log units) below the measured number, and the stated range ends below it.
By their numbers in this assay, from the lowest: compound 1; then compounds 2 and 3 (each within the scatter of the next); then compound 4.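

In this assay, a 3.3-fold higher number from compound 3 to compound 4 (0.52 log units; beyond the scatter), which makes nitro in place of cyano, on this aromatic carbon ortho to a trifluoromethyl group and para to a large group, a change toward a weaker inhibitor. Within the data shown here, this is the first pair that differs in one place, so the direction of this swap can now be read directly, with the rest of the structure held fixed, and no longer only loosely from compounds that differ elsewhere as well. Nothing shown here gives a measured property that would explain the step.

As far as these compounds go, whether the swap runs the same way and to a similar size on the core of compound 1 stays open, as this one pair speaks only for the core it shares. From the compounds shown here alone, it also remains open how other groups on this same aromatic carbon, such as an amine, a carboxylic acid or a simple chlorine atom, would stand against cyano and nitro in this assay.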